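Halophenyl swap on the enone arm of compound 1

The source may report more compounds than this note shows. Statements on the series, on what has been measured and on what is new or still open speak of the compounds shown alone.

Within the data shown here, compound 1 `O=C(COc1ccc(C(=O)/C=C/c2cccc(Cl)c2)cc1)N[C@H]1CCOC1=O` is the only member of the set that returns a number in a functional assay on MCF7 cells (Homo sapiens) for antiproliferative activity, read by MTT assay, with a stated time of 72 h (on this read-out lower numbers stand for stronger inhibition and higher numbers for weaker inhibition), where compound 1 gives 20900 nM. Compound 2 `O=C(CNc1cccc(Cl)c1)N[C@H]1CCOC1=O` reaches only a limit of the assay, giving > 64000 nM in this assay. Compound 3 `O=C(CNc1ccccc1)N[C@H]1CCOC1=O` likewise stops at a limit, with > 64000 nM. The move from compound 2 to compound 3, hydrogen in place of chloro on an aromatic carbon, is a step that the two limits leave unreadable from compound 2 to compound 3, both values sitting at the limit of > 64000 nM in this assay, at which 2 of the 3 values shown sit. Compound 1 thus stands alone as the sole measured point, with no readable step around it.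

Compound 4 `O=C(COc1ccc(C(=O)/C=C/c2ccc(Br)cc2)cc1)N[C@H]1CCOC1=O` differs from compound 1 in one place: 4-bromophenyl in place of 3-chlorophenyl on a double-bonded chain carbon bound to a double-bonded chain carbon. Among the measured compounds shown here, none of the measured steps touches this position or this pair of groups; the only computed step is unreadable and concerns a different part of the molecule. For the measured compounds named here, with no measured step bearing on the change, the expected step for compound 4 is a 1.0-fold lower number from compound 1 to compound 4 (0.02 log units; within the scatter), that is, none beyond the scatter. Compound 4 is therefore estimated at 20000 nM in this assay, with a range from 8000 nM to 50000 nM.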

Compound 4, half-maximal inhibitory concentration: > 64000 nM
Compound 4 gave a limit, no number; the forecaster's own chance of this, stated with the estimate: 15%; middle value at least 3.2-fold (0.50 log units) from the limit.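

Among these compounds, replacing 3-chlorophenyl with 4-bromophenyl on a double-bonded chain carbon bound to a double-bonded chain carbon gives the first readable step: in this assay, it is an at least 3.0-fold higher number from compound 1 to compound 4 (0.48 log units; beyond the scatter). Among the compounds shown here, this shows that the position is not indifferent to the halophenyl group it carries, and that the measurable activity of compound 1 does not survive this single change, which the earlier compounds could not show. The step gives only a minimum size and not an exact one, because compound 4 reaches a limit and not a number: the limit of > 64000 nM in this assay, at which 3 of the 4 values shown sit.

The swap changes the halogen and its place on the ring together, so the compounds shown do not tell which of the two accounts for the step, and a 3-bromophenyl or 4-chlorophenyl group at this position would separate them. As far as these compounds go, it also remains open how a plain phenyl group at the same position would read against compound 1, and whether any group here would give a lower number than compound 1 does.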